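Methylsulfonyl for Methoxycarbonyl: Expected Cytotoxicity of Compound 4

This account rests on a few compounds, and the source may have more. Where it says the series, first, only, none or still open, it means among the compounds named here.

Measured compounds:
compound 1 `COC(=O)c1cccc(C(=O)N2CCCC(C(=O)Nc3ccc(Cl)cc3)C2)c1` gives 0%
compound 2 `COC(=O)c1cc(-c2cccc(NC(=O)C3CCCN(C(=O)c4cc(C(F)(F)F)cc(C(F)(F)F)c4)C3)c2)co1` gives 0%
compound 3 `O=C(c1ccccc1)c1cccc(NC(=O)C2CCCN(C(=O)c3cc(C(F)(F)F)cc(C(F)(F)F)c3)C2)c1` gives 0%

In an ADME assay on PC-3 cells (Homo sapiens) for cytotoxicity, read by WST assay, tested at 100 uM (on this read-out lower numbers stand for less inhibition and higher numbers for more inhibition at the one concentration tested (going by the name of the read-out)), compound 1 gives 0% and stands level with compounds 2 and 3, all three within the scatter of one another. Among the compounds with values here, the only measured step between close neighbours, no change at the digits printed from compound 2 to compound 3 (within the scatter), concerns a different part of the shared core and was flat. Compound 4 `CS(=O)(=O)c1cccc(C(=O)N2CCCC(C(=O)Nc3ccc(Cl)cc3)C2)c1` differs from compound 1 by methylsulfonyl in place of methoxycarbonyl on an aromatic carbon. Within the data shown here, no measured step touches this change directly, and the one step that exists shows no movement. Compound 4 is therefore expected to stay flat, with the step of no change at the digits printed from compound 1 to compound 4 (within the scatter) not exceeding the scatter. The estimated value of compound 4 is 0%, with a range from 0% to 10%.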

Compound 4, a percentage reported as inhibition, at one concentration (the size of the read-out at that concentration, not a potency): 2%
Compound 4: the middle estimate sits 2 percentage points below what was measured; measured number inside the range.
By their numbers in this assay, from the lowest: compounds 1, 2, 3 and 4 (each within the scatter of the next).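

In this assay, methylsulfonyl in place of methoxycarbonyl on this aromatic carbon, meta to a large group, gives a number 2 percentage points higher from compound 1 to compound 4 (within the scatter). Within the data shown here, this is the first direct reading at this position, and it shows that this exchange leaves the result within the scatter. No evidence bears on why the result stays flat.

Going by these compounds, whether an amine or a carboxylic acid on this aromatic carbon would give a similar result remains open. The compounds shown also leave open whether any group here could move the read-out beyond the scatter.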